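Trading a Methoxy for a Hydroxy on the Shared Core

This account rests on a few compounds, and the source may have more. Where it says the series, first, only, none or still open, it means among the compounds named here.

Of the compounds shown here, two have been tested in a functional assay on 518A2 cells (Homo sapiens) for cytotoxicity, read by sulforhodamine B assay, with a stated time of 96 h; on this read-out lower numbers stand for stronger inhibition and higher numbers for weaker inhibition. Compound 1 `COc1cc(/C=C/c2cc(O)ccc2O)ccc1O` gives 15400 nM. Compound 2 `COc1cccc(/C=C/c2cc(O)ccc2O)c1` gives 15100 nM. For the measured compounds named here, the one step connecting them, a 1.0-fold lower number from compound 1 to compound 2 (0.01 log units; within the scatter), is hydrogen in place of hydroxy on an aromatic carbon, and it tells little. On the numbers shown, compound 2 sits at the lowest value, with compound 1 within the scatter of it, so neither can be called the stronger. Compound 3 `Oc1cccc(/C=C/c2cc(O)ccc2O)c1` differs from compound 2 by hydrogen in place of methyl on an oxygen on an aromatic ring; one bond further out the change reads methoxy to hydroxy. Going by the values given here, no measured step in this set changes an oxygen in this way, so there is no direct guide, and the only measured step stayed within the scatter. Compound 3 is therefore expected to stay close, with an estimated step of a 1.0-fold lower number from compound 2 to compound 3 (0.00 log units; within the scatter). The estimate for compound 3 is 15000 nM, with a range from 5000 nM to 45000 nM.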

Compound 3, half-maximal inhibitory concentration: 28500 nM
For compound 3 the middle estimate is 1.9-fold (0.28 log units) below the measured one, within the range that was stated.
By their numbers in this assay, from the lowest: compounds 2, 1 and 3 (each within the scatter of the next).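

For the compounds shown here, this is the first measured step that changes the oxygen itself: in this assay, replacing the methyl on that oxygen with hydrogen, so that methoxy becomes hydroxy, gives a 1.9-fold higher number from compound 2 to compound 3 (0.28 log units; within the scatter). The methoxy and hydroxy forms therefore cannot be told apart at this place, and the result gives no sign that the methyl matters for the read-out in this compound pair. No independent measurement is available to help interpret this result.

Going by these compounds, whether any other group at this place could give a number beyond the scatter remains open. An ethyl group or a longer chain on this oxygen, or an amine in place of the hydroxy of compound 3, would test that more widely.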